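The compounds below may be only part of what the source reports. "The series", "measured", "known", "first", "only" and "open" are said of these compounds alone.

In an ADME assay on S9 fraction from liver (Rattus norvegicus) for metabolic stability, read by LC-MS, using NADPH, with a stated time of 30 min (on this read-out higher numbers stand for a more stable compound and lower numbers for a less stable compound), three compounds sharing one core have been measured. Compound 1 `CCCCCCCCc1ccc(OCC(=O)Cn2ncnn2)cc1` gives < 5%, which is a limit of the assay and not a number. Compound 2 `CCCCCCCCc1ccc(OCC(=O)Cn2nnc(-c3cccc(C(=O)OC)c3)n2)cc1`, with 3-(methoxycarbonyl)phenyl on the aromatic carbon, gives 19%. Compound 3 `CCCCCCCCc1ccc(OCC(=O)Cn2nnc(-c3ccccn3)n2)cc1`, with pyridin-2-yl at that place, gives 30%, the higher of the two numbers. Both substituents raise the read-out relative to compound 1, as a number at least 14 percentage points higher from compound 1 to compound 2 (beyond the scatter) and a number at least 25 percentage points higher from compound 1 to compound 3 (beyond the scatter) show. The exchange of one substituent for the other is modest, at a number 11 percentage points higher from compound 2 to compound 3 (beyond the scatter).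

Compound 4 `CCCCCCCCc1ccc(OCC(=O)Cn2nnc(-c3cccc(C(=O)O)c3)n2)cc1` carries 3-carboxyphenyl in place of pyridin-2-yl on an aromatic carbon. Within the data shown here, no measured step covers a carboxyl group, so the closest guide is compound 2, whose 3-(methoxycarbonyl)phenyl group stands where compound 4 has 3-carboxyphenyl. Going back from pyridin-2-yl to that kind of substituent could cost part of the modest gain seen in a number 11 percentage points higher from compound 2 to compound 3 (beyond the scatter), but the expected change is small. The estimated step is a number 4 percentage points lower from compound 3 to compound 4 (within the scatter), slightly downward and not expected to lie beyond the scatter. In this assay, compound 4 is expected to give 26%, with an estimated range from 10% to 50%.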

Compound 4, percent of the compound remaining: < 5%
Compound 4: no number, only a limit; the forecaster's own chance of this, stated with the estimate: 7%; middle value at least 21 percentage points away from the limit.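

In this assay compound 4 gives < 5%, which is a limit of the assay and not a number. Among these compounds, the earlier compounds showed only that a substituted aromatic ring at this place, on the five-membered aromatic ring with 4 nitrogen, goes with a higher read-out than hydrogen, but this result shows that such a ring does not secure that gain: 3-carboxyphenyl in place of pyridin-2-yl gives a number at least 25 percentage points lower from compound 3 to compound 4 (beyond the scatter), and the loss of a single methyl from the ester gives a number at least 14 percentage points lower from compound 2 to compound 4 (beyond the scatter), so a small change on the outer ring decides much of the outcome. Any step between the two compounds at the limit cannot be read, because both values sit there: the limit of < 5% in this assay, at which 2 of the 4 values shown sit.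

The compounds shown leave open whether an amide in place of the carboxylic acid on that ring would keep the read-out near that of compound 2 or lose it as compound 4 does, and they give no cause for the drop. As far as these compounds go, it also remains open how an amine on that ring, or a shorter chain on the shared core, would move the read-out.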